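The source may hold more compounds than are shown below. What is called first, only, known or untested is meant among the compounds shown, and "the series" means these compounds.

Measured so far:
Compound 1 `C[C@H]1[C@H](NCc2cncs2)C[C@H]2C[C@@H]1C2(C)C` in an ADME assay on MDCK cells (Canis lupus familiaris) for cytotoxicity, read by microscopy, with a stated time of 48 h (a lower number here means that less compound is tolerated, a higher number that more compound is tolerated), gives only a limit, > 100000 nM.
Compound 2 `C[C@H]1[C@H](NCc2ccc(Br)s2)C[C@H]2C[C@@H]1C2(C)C` gives 43000 nM.
Compound 3 `C[C@H]1[C@H](NCc2ccco2)C[C@H]2C[C@@H]1C2(C)C` gives 50000 nM.

Compound 2 holds the lowest of the two numbers shown, with compound 3 inside the scatter of it: a 1.2-fold higher number from compound 2 to compound 3 (0.07 log units; within the scatter). Compound 1 stands at the limit of > 100000 nM in this assay, at which 1 of the 3 values shown sits.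

Compound 4 `C[C@H]1[C@H](NCc2ccc(-c3ccc(Br)s3)s2)C[C@H]2C[C@@H]1C2(C)C` differs from compound 2 by 5-bromothiophen-2-yl in place of bromo on an aromatic carbon. The measured step that bears on this is an at least 2.3-fold lower number from compound 1 to compound 2 (0.36 log units; beyond the scatter), where a 5-bromothiophen-2-yl entered; a 1.2-fold higher number from compound 2 to compound 3 (0.07 log units; within the scatter) adds nothing beyond the scatter. A second 5-bromothiophen-2-yl is expected to push the number further down, by about a 2.2-fold lower number from compound 2 to compound 4 (0.33 log units; beyond the scatter). Compound 4 is therefore estimated at 20000 nM, with a range from 7000 nM to 60000 nM.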

Compound 4, minimum cytotoxic concentration: 780 nM
The estimate for compound 4 lay 26-fold (1.41 log units) above the measured number; measured number outside the range, below it.
By their numbers in this assay, from the lowest: compound 4; then compounds 2 and 3 (each within the scatter of the next). At a limit, above all of these: compound 1.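

Among these compounds, at the aromatic carbon next to the ring sulfur, the series is far more sensitive than the earlier compounds showed: in this assay, 5-bromothiophen-2-yl in place of bromo gives a 55-fold lower number from compound 2 to compound 4 (1.74 log units; beyond the scatter). Exchanging the whole ring on the chain carbon gave only a 1.2-fold higher number from compound 2 to compound 3 (0.07 log units; within the scatter), so extension at this carbon counts for much more here than that exchange. Nothing measured on these compounds accounts for the size of this step.

From the compounds shown here alone, whether the second thiophene ring or its bromo carries the step remains open. So does the outcome with an unsubstituted phenyl, an amine or a carboxylic acid at this carbon.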